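Dimethoxyphenyl Analogue of a Thiourea: Expected Cytotoxicity

The source may report more compounds than this note shows. Statements on the series, on what has been measured and on what is new or still open speak of the compounds shown alone.

Compound 1 `O=C(NC(=S)Nc1cccc(-c2nc3ccccc3[nH]2)c1)c1ccccc1`: > 10000 nM
Compound 2 `CCOc1ccc(C(=O)NC(=S)Nc2cccc(-c3nc4ccccc4[nH]3)c2)cc1OCC`: 8000 nM

In a functional assay on HUVEC cells (Homo sapiens) for cytotoxicity, read by WST assay, with a stated time of 48 h (on this read-out higher numbers stand for weaker inhibition and lower numbers for stronger inhibition), compound 1 reaches only (the limit of > 10000 nM in this assay, at which 1 of the 2 values shown sits), so its standing here is a limit, not a number. Compound 2 gives 8000 nM in this assay. Compound 3 , `COc1ccc(C(=O)NC(=S)Nc2cccc(-c3nc4ccccc4[nH]3)c2)cc1OC`, differs from compound 1 by 3,4-dimethoxyphenyl in place of phenyl on a carbonyl carbon. Going by the values given here, no step between measured compounds is known, and the step of an at least 1.1-fold lower number from compound 1 to compound 3 (0.04 log units; that floor lies within the scatter) is expected to be none beyond the scatter, since compound 2 gives 8000 nM in this assay. For compound 3 the estimated value is 9000 nM, ranging from 4000 nM to 20000 nM, with a fair chance of another limit.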

Compound 3, half-maximal inhibitory concentration: 6000 nM
Compound 3: the middle estimate sits 1.5-fold (0.18 log units) above what was measured; low and high end bracket the measured number.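

Going by these compounds alone, at this position, on a carbonyl carbon, this assay now gives a first readable step for 3,4-dimethoxyphenyl in place of phenyl: an at least 1.6-fold lower number from compound 1 to compound 3 (0.22 log units; that floor lies within the scatter). This step is a floor and not a size, because compound 1 stands only as a limit of the assay: the limit of > 10000 nM in this assay, at which 1 of the 3 values shown sits.

The values leave open how far the true step extends, and whether it passes beyond the scatter. They also leave open whether an amine, a carboxylic acid or a single methoxy group on the phenyl ring would move the number further.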